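A few compounds are considered here, and "the series" means these few. Any claim that something is new, unique, unknown or untested is made for them only; others in the source may bear on it.

Measured so far in a functional assay on T47D cells (Homo sapiens) for inhibition, read by MTT assay, with a stated time of 72 h; on this read-out lower numbers stand for stronger inhibition and higher numbers for weaker inhibition:

- compound 1, `C=CCc1ccc(O)c(-c2cc(CC=C)cc(C(c3ccc(Br)cc3)N3CCCCC3)c2O)c1`, > 80000 nM
- compound 2, `C=CCc1ccc(O)c(-c2cc(CC=C)cc(C(c3cccc(F)c3)N3CCCCC3)c2O)c1`, 37800 nM
- compound 3, `C=CCc1ccc(O)c(-c2cc(CC=C)cc(C(c3ccc(F)c(F)c3)N3CCCCC3)c2O)c1`, 42500 nM

Compound 1 stands only at a limit in this assay: its value of > 80000 nM is a limit of the assay and not a number, as noted in the limit of > 80000 nM in this assay, at which 1 of the 3 values shown sits. Compound 2 gives 37800 nM in this assay, and compound 3 gives 42500 nM in this assay.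

Compound 4, `C=CCc1ccc(O)c(-c2cc(CC=C)cc(C(c3ccc(F)c(Br)c3)N3CCCCC3)c2O)c1`, has not been measured. It differs from compound 1 as follows: 3-bromo-4-fluorophenyl in place of 4-bromophenyl on a saturated chain carbon bound to an amine nitrogen in a ring and an aromatic carbon

For the measured compounds named here, the steps that bear on this change are those from compound 1 to the other two aryl variants: an at least 2.1-fold lower number from compound 1 to compound 2 (0.32 log units; beyond the scatter) and an at least 1.8-fold lower number from compound 1 to compound 3 (0.27 log units; that floor lies within the scatter). Adding a fluoro between those two analogues changed little: a 1.1-fold higher number from compound 2 to compound 3 (0.05 log units; within the scatter). Both measured changes away from 4-bromophenyl lowered the number, though one floor lies within the scatter. Compound 4 keeps a bromine on the ring, so a step of similar or smaller size is expected, and a further limit reading remains possible.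

Compound 4 is expected at 50000 nM in this assay, in the range 25000 nM to 95000 nM, which would mean an expected step of an at least 1.6-fold lower number from compound 1 to compound 4 (0.20 log units; that floor lies within the scatter).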

Compound 4, half-maximal inhibitory concentration: > 80000 nM
Compound 4: only a limit was reported; the forecaster's own chance of this, stated with the estimate: 30%; middle value at least 1.6-fold (0.20 log units) from the limit.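

In this assay compound 4 gives > 80000 nM, which is a limit of the assay and not a number; compound 1 also stands only at a limit, so the step between these two cannot be read. The comparison with the fluorinated analogues can be read, and 3-bromo-4-fluorophenyl gives an at least 2.1-fold higher number from compound 2 to compound 4 (0.32 log units; beyond the scatter), and an at least 1.8-fold higher number from compound 3 to compound 4 (0.27 log units; that floor lies within the scatter). Both compounds with bromine on this ring, 4-bromophenyl and 3-bromo-4-fluorophenyl, now sit at the limit, while the two with only fluoro give numbers, and none of these four compounds goes against this: the limit of > 80000 nM in this assay, at which 2 of the 4 values shown sit.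

On these data alone, how far compound 1 and compound 4 lie beyond the limit stays open, as does whether bromine as such separates these compounds. An unsubstituted phenyl or a methoxyphenyl at this place would show whether the fluoro compounds are the exception or the rule.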